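A few compounds are considered here, and "the series" means these few. Any claim that something is new, unique, unknown or untested is made for them only; others in the source may bear on it.

The measured compounds:
compound 1 `COc1cc(-c2nnc(SCC(=O)c3ccc(Br)cc3)n2N)cc(OC)c1OC`, which in a functional assay on HCT-116 cells (Homo sapiens) for antiproliferative activity, read by MTT assay, with a stated time of 48 h (a higher number here means a weaker inhibitor, a lower number a stronger inhibitor), gives 9230 nM
compound 2 `COc1cc(-c2nnc(SCC(=O)c3ccc(C)cc3)n2N)cc(OC)c1OC`, for which compound 2 gives 370 nM
compound 3 `COc1cc(-c2nnc(SCC(=O)c3cccc(Br)c3)n2N)cc(OC)c1OC`, for which compound 3 gives 5320 nM

Compound 2 has the lowest number of the three: its nearest neighbour is compound 3 (a 14-fold higher number from compound 2 to compound 3 (1.16 log units; beyond the scatter)) and the furthest is compound 1 (a 25-fold lower number from compound 1 to compound 2 (1.40 log units; beyond the scatter)). Compound 4 `COc1cc(-c2nnc(SCC(=O)c3ccc(F)c(F)c3)n2N)cc(OC)c1OC` has not been measured. It differs from compound 2 by 3,4-difluorophenyl in place of 4-methylphenyl on a carbonyl carbon. Among the measured compounds shown here, two measured steps bear on this change: a 25-fold lower number from compound 1 to compound 2 (1.40 log units; beyond the scatter) and a 14-fold higher number from compound 2 to compound 3 (1.16 log units; beyond the scatter), both large, both showing a much higher number when a bromo-bearing ring stands where the methyl-bearing ring does, while a 1.7-fold lower number from compound 1 to compound 3 (0.24 log units; within the scatter) lies within the scatter. No fluoro-bearing ring has been measured. Compound 4 is therefore expected to move to a higher number, beyond the scatter, by about a 6.8-fold higher number from compound 2 to compound 4 (0.83 log units; beyond the scatter). Compound 4 is estimated at 2500 nM, with a range from 600 nM to 9000 nM.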

Compound 4, half-maximal inhibitory concentration: 10400 nM
Beside the measured number, compound 4's estimate is 4.2-fold (0.62 log units) below it; measured number outside the range, above it.
By their numbers in this assay, from the lowest: compound 2; then compounds 3, 1 and 4 (each within the scatter of the next).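

In this assay, a ring with two fluoro groups and no bromo also stands far from the 4-methylphenyl ring on this carbonyl carbon (a 28-fold higher number from compound 2 to compound 4 (1.45 log units; beyond the scatter)), so the gap is not confined to bromo-bearing rings. The 3,4-difluorophenyl ring cannot be told apart from either bromophenyl ring (a 2.0-fold higher number from compound 3 to compound 4 (0.29 log units; within the scatter); a 1.1-fold higher number from compound 1 to compound 4 (0.05 log units; within the scatter)), which leaves compound 2 alone among the four. Nothing given here accounts for this difference. From the compounds shown here alone, whether an unsubstituted phenyl, 4-ethylphenyl or 4-methoxyphenyl ring would stay near compound 2 remains open. So does whether a 3-methylphenyl ring would.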